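Phenyl in Place of Bromo: Expecting Little Change

The source may hold more compounds than are shown below. What is called first, only, known or untested is meant among the compounds shown, and "the series" means these compounds.

Of the compounds shown here, three sharing one core have been measured in a functional assay on HeLa cells (Homo sapiens) for antiproliferative activity, with a stated time of 24 h; a higher number here means a weaker inhibitor, a lower number a stronger inhibitor. Compound 1 `NC(=O)c1c(NC(=O)c2ccccc2Cl)sc2c1CCN(Cc1ccc(Cl)cc1Cl)C2` gives 21100 nM. Compound 2 `NC(=O)c1c(NC(=O)c2ccccc2Cl)sc2c1CCN(C(=S)Nc1cccc3ccccc13)C2` gives 30800 nM. Compound 3 `NC(=O)c1c(NC(=O)c2ccccc2Cl)sc2c1CCN(C(=S)Nc1ccccc1Br)C2` gives 24600 nM, which sits second highest of the three; the nearest number is that of compound 1 and the furthest that of compound 2, yet both gaps lie within the scatter. The step of a 1.2-fold higher number from compound 1 to compound 3 (0.07 log units; within the scatter) and the step of a 1.3-fold lower number from compound 2 to compound 3 (0.10 log units; within the scatter) were both within the scatter, so neither exchange of the group on the amine nitrogen in a ring moved the number noticeably.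

Compound 4 `NC(=O)c1c(NC(=O)c2ccccc2Cl)sc2c1CCN(C(=S)Nc1ccccc1-c1ccccc1)C2` is not yet measured. It differs from compound 3 by phenyl in place of bromo on an aromatic carbon. Among the measured compounds shown here, the step that bears most on this is a 1.3-fold lower number from compound 2 to compound 3 (0.10 log units; within the scatter), which exchanged the aromatic group on the amide-type nitrogen without effect beyond the scatter, and the change to compound 4 again alters only that group. No shift beyond the scatter is therefore expected, so compound 4 is expected to give 25000 nM, with a range from 10000 nM to 60000 nM, meaning an expected step of a 1.0-fold higher number from compound 3 to compound 4 (0.01 log units; within the scatter).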

Compound 4, half-maximal inhibitory concentration: 24000 nM
For compound 4 the middle estimate is 1.0-fold (0.02 log units) above the measured one, and the stated range covers the measured number.
By their numbers in this assay, from the lowest: compounds 1, 4, 3 and 2 (each within the scatter of the next).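

In this assay, putting phenyl in place of bromo on this aromatic carbon, ortho to a large group, gives a 1.0-fold lower number from compound 3 to compound 4 (0.01 log units; within the scatter), so this exchange, with its added ring, leaves the number unchanged within the scatter. The earlier steps shown here replaced whole groups, whereas this one changes a single substituent on a ring that stays in place, and 2-phenylphenyl in place of naphthalen-1-yl likewise gives a 1.3-fold lower number from compound 2 to compound 4 (0.11 log units; within the scatter). Nothing available here explains why the number holds steady across these changes.

The compounds shown leave open whether a different kind of group on this carbon, such as an amine or a carboxylic acid, would shift the number beyond the scatter. They also leave open what a plain phenyl ring, with hydrogen on this carbon, would give.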